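Chloro in place of the amine side chain: notes

A few compounds are considered here, and "the series" means these few. Any claim that something is new, unique, unknown or untested is made for them only; others in the source may bear on it.

Measured compounds in a functional assay on SK-OV-3 cells (Homo sapiens) for cytotoxicity, read by MTT assay, with a stated time of 48 h; a lower number here means a stronger inhibitor, a higher number a weaker inhibitor:
compound 1 `CN(C)CCNc1ccnc2cc(OCc3ccc(F)cc3)ccc12` — 890 nM
compound 2 `C=CCOc1ccc2c(NCCN(C)C)ccnc2c1` — 1560 nM
compound 3 `CCOc1ccc2c(NCCN(C)C)ccnc2c1` — 4620 nM

Compound 1 gives the lowest number of the three. Compound 2 sits closest, with a 1.8-fold higher number from compound 1 to compound 2 (0.24 log units; within the scatter), so the two cannot be ordered. Compound 3 is furthest, with a 5.2-fold higher number from compound 1 to compound 3 (0.72 log units; beyond the scatter), and between the two smaller ether groups there is a 3.0-fold higher number from compound 2 to compound 3 (0.47 log units; beyond the scatter). All three measured steps vary the group on the ether oxygen and leave the rest of the shared core unchanged.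

Compound 4 `Fc1ccc(COc2ccc3c(Cl)ccnc3c2)cc1` is the next compound to be measured. Relative to compound 1 the change is elsewhere: chloro in place of (2-(dimethylamino)ethyl)amino on an aromatic carbon. For the measured compounds named here, no measured step touches this position, so the measured series gives no direct guide to the size of the step. The change removes the whole six-heavy-atom chain with its one hydrogen-bond donor and two hydrogen-bond acceptors and leaves a single chlorine in its place, a far larger alteration than any ether swap seen so far. A loss of potency is expected for compound 4, estimated at 9000 nM (range 2000 nM to 40000 nM), corresponding to an expected 10-fold higher number from compound 1 to compound 4 (1.00 log units; beyond the scatter). The wide range reflects the absence of any measured analogue at this position.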

Compound 4, half-maximal inhibitory concentration: 2780 nM
Compound 4: middle estimate off by 3.2-fold (0.51 log units), on the high side; low and high end bracket the measured number.
By their numbers in this assay, from the lowest: compounds 1, 2, 4 and 3 (each within the scatter of the next, the first and the last beyond it).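

For the compounds shown here, this is the first reading at the aromatic carbon opposite the ring nitrogen: in this assay, chloro in place of (2-(dimethylamino)ethyl)amino gives a 3.1-fold higher number from compound 1 to compound 4 (0.49 log units; beyond the scatter), a step beyond the scatter but modest in size. The side chain is therefore not needed for a measurable cytotoxic read-out, as compound 4 still gives 2780 nM without any amine at this position, although compound 1 retains the lower number. No supporting data bear on why removing the chain costs only this much, so the result stands as an observation without a mechanism.

The compounds shown place only chloro and (2-(dimethylamino)ethyl)amino at this position, leaving open how a shorter amine, a longer chain such as (3-(dimethylamino)propyl)amino, a morpholine ring or a methoxy group would compare with them. As far as these compounds go, it also remains open whether a step of this size would recur on the ether groups of compound 2 and compound 3, since chloro has so far been read only with the 4-fluorophenyl ether group of compound 1.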